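Urea Series: Replacing the Tert-Butyl Aryl Group

A few compounds are considered here, and "the series" means these few. Any claim that something is new, unique, unknown or untested is made for them only; others in the source may bear on it.

Measured compounds:
compound 1 `CC(C)c1cccc(C(C)C)c1NC(=O)NCC1(c2ccc(C(C)(C)C)cc2)CCCC1` — 63 nM
compound 2 `CC(C)c1cccc(C(C)C)c1NC(=O)NCC1(c2ccc(F)cc2)CCCC1` — 23 nM
compound 3 `COc1ccc(C2(CNC(=O)Nc3c(C(C)C)cccc3C(C)C)CCCC2)cc1` — 31 nM

Three ureas share one core and differ only in the aryl group on the five-membered ring. In an assay on microsomes for inhibition of acyl-CoA:cholesterol acyltransferase (Oryctolagus cuniculus) (on this read-out higher numbers stand for weaker inhibition and lower numbers for stronger inhibition), compound 1 gives 63 nM, the highest of the three numbers; compound 2 gives 23 nM and compound 3 gives 31 nM. The step of a 2.7-fold lower number from compound 1 to compound 2 (0.44 log units; beyond the scatter) and the step of a 2.0-fold lower number from compound 1 to compound 3 (0.31 log units; beyond the scatter) both go downward by a modest amount, while a 1.3-fold higher number from compound 2 to compound 3 (0.13 log units; within the scatter) shows no separation between those two.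

Compound 4 `COC(=O)c1cccc(C2(CNC(=O)Nc3c(C(C)C)cccc3C(C)C)CCCC2)c1` is the next compound, differing from compound 1 in one place: 3-(methoxycarbonyl)phenyl in place of 4-(tert-butyl)phenyl on a saturated ring carbon. Within the data shown here, no measured compound carries a methoxycarbonyl group, nor any group on that position of the aryl ring, so the two downward steps from compound 1 are the only guide, and both point to a modest lowering when the tert-butyl group leaves. Compound 4 is therefore expected to lie somewhat below compound 1, with the step of a 1.7-fold lower number from compound 1 to compound 4 (0.22 log units; within the scatter) estimated as modest. The estimate for compound 4 in this assay is 38 nM, in the range 13 nM to 110 nM.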

Compound 4, half-maximal inhibitory concentration: 34 nM
For compound 4 the middle estimate is 1.1-fold (0.05 log units) above the measured one; measured number inside the range.
By their numbers in this assay, from the lowest: compounds 2, 3, 4 and 1 (each within the scatter of the next, the first and the last beyond it).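

With 3-(methoxycarbonyl)phenyl in place of 4-(tert-butyl)phenyl, this assay gives a 1.9-fold lower number from compound 1 to compound 4 (0.27 log units; within the scatter), so unlike the fluoro and methoxy replacements, this change from compound 1 does not clear the scatter. Compound 4 also cannot be separated from the other two replacements, with a 1.1-fold higher number from compound 3 to compound 4 (0.04 log units; within the scatter) and a 1.5-fold higher number from compound 2 to compound 4 (0.17 log units; within the scatter), which shows that a methoxycarbonyl group on a differently numbered aryl carbon gives a number in the same range as theirs. Nothing available explains this result.

Both the group and its place on the aryl ring change in the step from compound 1, and the compounds shown cannot separate these two changes. As far as these compounds go, it also remains open what a carboxylic acid or an amine would give in place of the methoxycarbonyl group.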